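Lactone to lactam on a styryl pyranone scaffold

The source may report more compounds than this note shows. Statements on the series, on what has been measured and on what is new or still open speak of the compounds shown alone.

For the measured compounds named here, compound 2 `COc1cc(/C=C/C2CC=CC(=O)O2)cc(OC)c1OC` gives 18.8 uM in a functional assay on HT-29 cells (Homo sapiens) for inhibition, read by sulforhodamine B assay, with a stated time of 48 h (on this read-out lower numbers stand for stronger inhibition of growth and higher numbers for weaker inhibition of growth), the highest of the two numbers so far; its neighbour compound 1 `COc1cc(/C=C/C2CC=CC(=O)O2)cc(OC)c1` gives 8.2 uM, and the step of a 2.3-fold higher number from compound 1 to compound 2 (0.36 log units; beyond the scatter) is a methoxy in place of hydrogen on an aromatic carbon. Compound 3 `COc1cc(/C=C/C2CC=CC(=O)N2)cc(OC)c1OC` differs from compound 2 by a group of 7 heavy atoms (5 carbon, 1 nitrogen, 1 oxygen; one six-membered non-aromatic ring with 1 hetero atom) in place of a group of 7 heavy atoms (5 carbon, 2 oxygen; one six-membered non-aromatic ring with 1 hetero atom), on a double-bonded chain carbon bound to a double-bonded chain carbon. No measured step touches this ring, so nothing shown bears directly on it. Compound 3 is expected to give 60 uM (range 15 uM to 200 uM), a step of a 3.2-fold higher number from compound 2 to compound 3 (0.50 log units; beyond the scatter) in this assay, and this is an estimate only.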

Compound 3, concentration for growth inhibition (reported as GI): > 864 uM
Compound 3: only a limit was reported; the forecaster's own chance of this, stated with the estimate: 30%; at least 14-fold (1.15 log units) between middle value and limit.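

At this position the ring itself matters: exchanging the six-membered ring of 5 carbon and 2 oxygen for the one of 5 carbon, 1 nitrogen and 1 oxygen gives an at least 45-fold higher number from compound 2 to compound 3 (1.66 log units; beyond the scatter) in this assay, a large step where the methoxy change gave only a modest one, a 2.3-fold higher number from compound 1 to compound 2 (0.36 log units; beyond the scatter). Compound 3 gives only a limit, not a number: the limit of > 864 uM in this assay, at which 1 of the 3 values shown sits.

The compounds shown leave open whether a methyl group on the ring nitrogen would bring growth inhibition back. They also leave open whether the same ring exchange would weaken compound 1 as strongly.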